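The compounds below may be only part of what the source reports. "The series", "measured", "known", "first", "only" and "open" are said of these compounds alone.

Compound 1 `COCCOc1cc(NC(=O)NCc2cc(C)c(-c3cn(C)nc3C(F)(F)F)nn2)cc(Cl)n1`: in a functional assay on HFL1 cells for antagonist activity at sphingosine 1-phosphate receptor 2 (Homo sapiens), read by ELISA, with a stated time of 24 h, in the presence of a further agent that is not named here (on this read-out higher numbers stand for weaker inhibition and lower numbers for stronger inhibition), compound 1 gives 3220000 nM.
Compound 2 `Cc1cc(CNC(=O)Nc2cc(OCC(O)CO)nc(C(F)(F)F)c2)nnc1-c1cn(C)nc1C(F)(F)F`: in this assay compound 2 gives only a limit, > 10000000 nM.
Compound 3 `Cc1cc(CNC(=O)Nc2cc(OCCO)nc(C(F)(F)F)c2)nnc1-c1cn(C)nc1C(F)(F)F`: in this assay compound 3 gives 810000 nM.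

Compound 3 has the lowest of the two numbers shown; compound 1 stands at a higher number, beyond the scatter, and compound 2 reports a limit and no number. For the measured compounds named here, the single measured step, an at least 12-fold lower number from compound 2 to compound 3 (1.09 log units; beyond the scatter), concerns the side chain on the oxygen and not the ring carbon. Compound 4 `Cc1cc(CNC(=O)Nc2cc(C(F)(F)F)nc(OCCO)c2C)nnc1-c1cn(C)nc1C(F)(F)F` differs from compound 3 at that ring carbon: methyl in place of hydrogen on an aromatic carbon. No measured step touches a change of this kind, so the one step shown gives no guide to its direction or size, and a small methyl is the only addition. For compound 4 in this assay a step of a 1.1-fold higher number from compound 3 to compound 4 (0.05 log units; within the scatter) is expected, which is to say no change beyond the scatter, with wide uncertainty. The estimate for compound 4 is 900000 nM, with a range from 250000 nM to 3500000 nM.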

Compound 4, half-maximal inhibitory concentration: 256000 nM
For compound 4 the middle estimate is 3.5-fold (0.55 log units) above the measured one, within the range that was stated.
By their numbers in this assay, from the lowest: compound 4; then compound 3; then compound 1. At a limit, above all of these: compound 2.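

In this assay, for the compounds shown here, methyl in place of hydrogen on this aromatic carbon gives a 3.2-fold lower number from compound 3 to compound 4 (0.50 log units; beyond the scatter), the first measured change at the ring rather than on the side chain. The carbon ortho to a 2-hydroxyethoxy group and para to a trifluoromethyl group therefore accepts this one-carbon addition, and here the number falls rather than rises. This rests on one pair of compounds, and nothing measured here bears on the cause of the step.

Going by these compounds, whether a larger group at this carbon, such as ethyl, or a different one, such as chlorine, a methoxy group or an amine, would move the number the same way remains open. Also open, on these data alone, is whether methyl has a similar effect alongside the side chains of compound 1 and compound 2.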